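The compounds below may be only part of what the source reports. "The series", "measured", "known", "first", "only" and "open" are said of these compounds alone.

In an in vitro ADME assay on microsomes from liver (Homo sapiens) for metabolic stability (a higher number here means faster removal of the compound, a lower number slower removal), compound 1 (`O=C(COCc1ccccc1)N1CCN(c2cccc(Cl)c2)CC1`) gives 310 mL.min-1.g-1 and compound 2 (`O=C(COCc1ccccc1)N1CCN(c2ccc(Cl)cc2Cl)CC1`) gives 450 mL.min-1.g-1. Within the data shown here, these two cannot be told apart, since the only measured step is a 1.5-fold higher number from compound 1 to compound 2 (0.16 log units; within the scatter). Among the measured compounds shown here, compound 2 therefore stands level with its one neighbour.

Compound 3 (`O=C(COCc1ccncn1)N1CCN(c2ccc(Cl)cc2Cl)CC1`) carries a single change from compound 2: pyrimidin-4-yl in place of phenyl on a saturated chain carbon bound to an oxygen on a saturated carbon. This places pyrimidin-4-yl in place of phenyl on a saturated chain carbon bound to an oxygen on a saturated carbon, so benzyloxy becomes (pyrimidin-4-yl)methoxy. For the measured compounds named here, the one measured step altered a different group and leaves the benzyl untouched, so it gives no direct measure of this swap. The expectation is therefore a judgement, and it points to a lower number, beyond the scatter. The expected step is a 3.0-fold lower number from compound 2 to compound 3 (0.48 log units; beyond the scatter). Compound 3 is estimated at 150 mL.min-1.g-1, with an expected range from 60 mL.min-1.g-1 to 380 mL.min-1.g-1.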

Compound 3, intrinsic clearance in microsomes: 17 mL.min-1.g-1
Beside the measured number, compound 3's estimate is 8.8-fold (0.95 log units) above it; measured number outside the range, below it.
By their numbers in this assay, from the lowest: compound 3; then compounds 1 and 2 (each within the scatter of the next).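

In this assay, changing the chlorine pattern on the aryl ring gave a step within the scatter, whereas the ring on the saturated chain carbon bound to an oxygen on a saturated carbon produces a large one: a 26-fold lower number from compound 2 to compound 3 (1.42 log units; beyond the scatter). This position is therefore sensitive, at least in the 2,4-dichlorophenyl compounds shown, since the swap keeps the 6 heavy atoms and one six-membered aromatic ring but exchanges carbon for 2 nitrogen and adds 2 hydrogen-bond acceptors. Nothing available explains why the number drops so sharply.

Going by these compounds, whether one ring nitrogen would be enough remains open, as a pyridin-4-yl group at this position would show. It is also unknown whether the same swap would bring a similar drop with the 3-chlorophenyl group of compound 1 in place.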